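A few compounds are considered here, and "the series" means these few. Any claim that something is new, unique, unknown or untested is made for them only; others in the source may bear on it.

Measured compounds:
compound 1, `CCN1CCN(c2cc(C)c3cc(NC(=O)c4cccc(Cl)c4)ccc3n2)CC1` — 3820 nM
compound 2, `CCN(CC)c1cc(C)c2cc(NC(=O)c3ccc(Cl)c(Cl)c3)ccc2n1` — > 50000 nM

Going by the values given here, in a functional assay on MCF7 cells (Homo sapiens) for antiproliferative activity, read by MTT assay, with a stated time of 72 h (on this read-out higher numbers stand for weaker inhibition and lower numbers for stronger inhibition), compound 1 gives 3820 nM, which is the only actual number in the set. The value for compound 2, > 50000 nM, is a limit of the assay and not a number; it places compound 2 at the limit of > 50000 nM in this assay, at which 1 of the 2 values shown sits. Among the compounds with values here, compound 1 thus stands alone as the one compound with a measured inhibitory concentration, and no two measured compounds differ in only one place, so no measured step can be followed.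

Compound 3, `CCN1CCN(c2cc(C)c3cc(NC(=O)c4ccco4)ccc3n2)CC1`, has not yet been measured in this assay. It differs from compound 1 by furan-2-yl in place of 3-chlorophenyl on a carbonyl carbon. Within the data shown here, no measured compound carries the entering group, so the two values shown say nothing directly about this change. The expectation is a moderate loss of potency, somewhat beyond the usual scatter, estimated as a 2.4-fold higher number from compound 1 to compound 3 (0.37 log units; beyond the scatter). Compound 3 is therefore expected to give about 9000 nM in this assay, with an estimated range from 2500 nM to 30000 nM.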

Compound 3, half-maximal inhibitory concentration: 41200 nM
Estimate against measurement, compound 3: 4.6-fold (0.66 log units) below; the measured number lies above the stated range.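

On the carbonyl carbon whose other neighbour is the amide-type nitrogen, the group is not interchangeable in this assay: furan-2-yl in place of 3-chlorophenyl gives an 11-fold higher number from compound 1 to compound 3 (1.03 log units; beyond the scatter). Going by these compounds alone, this is the first measured step, and it shows that activity depends on the group at this place while the rest of compound 1 stays the same. Nothing shown bears on the cause of this step.

The step combines two changes, the loss of the chlorine and the replacement of a six-membered aromatic ring of carbon only by a five-membered aromatic ring with one hetero atom, so an unsubstituted phenyl or a thiophen-2-yl on the same carbonyl carbon would be needed to separate them. Within the data shown here, compound 2 gives only a limit of the assay, not a number, and differs from compound 1 in more than one place, so it adds no step and leaves the rest of the structure unresolved.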